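The source may report more compounds than this note shows. Statements on the series, on what has been measured and on what is new or still open speak of the compounds shown alone.

Compound 1, `FC(F)(F)c1ccc(CSc2nc(N3CCCCC3)c3ccccc3n2)cc1`: in a functional assay on MCF7 cells (Homo sapiens) for cytotoxicity, read by MTT assay, with a stated time of 72 h (on this read-out lower numbers stand for stronger inhibition and higher numbers for weaker inhibition), compound 1 gives > 50000 nM, which is a limit of the assay and not a number.
Compound 2, `CCOc1ccccc1Nc1nc(SCc2ccc(C(F)(F)F)cc2)nc2ccccc12`: in this assay compound 2 gives > 50000 nM, again a limit rather than a number.

Compound 2 therefore stands only at the limit of > 50000 nM in this assay, at which 2 of the 2 values shown sit, with no number to place it more closely. Within the data shown here, the single measured step, a step that the two limits leave unreadable from compound 1 to compound 2, cannot be read. Compound 3, `FC(F)(F)c1ccc(CSc2nc(Nc3cccc(C(F)(F)F)c3)c3ccccc3n2)cc1`, differs from compound 2 by 3-(trifluoromethyl)phenyl in place of 2-ethoxyphenyl on a nitrogen on an aromatic ring. Among the measured compounds shown here, no measured step bears on this change, so no step beyond the scatter is expected in this assay in either direction. Compound 3 is accordingly estimated at 50000 nM, within 20000 nM to 100000 nM, an expected step of a number no higher from compound 2 to compound 3 (the limit leaves the size open).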

Compound 3, half-maximal inhibitory concentration: 15300 nM
Beside the measured number, compound 3's estimate is 3.3-fold (0.51 log units) above it, outside the stated range (below it).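

In this assay, among these compounds, the group on the nitrogen proves able to move the read-out: 3-(trifluoromethyl)phenyl in place of 2-ethoxyphenyl gives an at least 3.2-fold lower number from compound 2 to compound 3 (0.51 log units; beyond the scatter) and yields the only actual number so far. The change from piperidin-1-yl to the (3-(trifluoromethyl)phenyl)amino group gives an at least 3.2-fold lower number from compound 1 to compound 3 (0.51 log units; beyond the scatter) in the same assay. On these data alone, both steps start from a limit, so their full size stays open: the limit of > 50000 nM in this assay, at which 2 of the 3 values shown sit.

The step from compound 1 to compound 2 still cannot be read. As far as these compounds go, how a nitrile or a carboxylic acid in place of the trifluoromethyl group would read remains open.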